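Notes on amine replacements in a potent antagonist series

A few compounds are considered here, and "the series" means these few. Any claim that something is new, unique, unknown or untested is made for them only; others in the source may bear on it.

Measured so far:
compound 1 `CC(C(=O)NCc1ccc(C(F)(F)F)nc1N1CCCC1)c1ccc(NS(C)(=O)=O)c(F)c1`, 0.6 nM
compound 2 `CC(C(=O)NCc1ccc(C(F)(F)F)nc1N1CCC(c2ccccc2)CC1)c1ccc(NS(C)(=O)=O)c(F)c1`, 0.6 nM

In a functional assay on CHO-K1 cells for antagonist activity at transient receptor potential cation channel subfamily V member 1 (Homo sapiens), read by FLIPR (on this read-out lower numbers stand for stronger inhibition and higher numbers for weaker inhibition), compound 2 gives 0.6 nM and stands level with compound 1, which gives 0.6 nM in this assay. Within the data shown here, the only measured step, no change at the digits printed from compound 1 to compound 2 (within the scatter), shows that swapping the whole saturated amine on the shared core left the read-out where it was.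

Compound 3 `CC(C(=O)NCc1ccc(C(F)(F)F)nc1N1CCC(C(F)(F)F)CC1)c1ccc(NS(C)(=O)=O)c(F)c1` differs from compound 2 by trifluoromethyl in place of phenyl on a saturated ring carbon. This change sits within the same saturated amine that was already exchanged without effect between compound 1 and compound 2, so no step beyond the scatter is expected in this assay in either direction. Among the measured compounds shown here, the change is smaller than the one from compound 1 to compound 2, which supports the same reading.

Compound 3 is therefore expected to give 0.8 nM in this assay, within 0.3 nM to 3 nM, an expected step of a 1.3-fold higher number from compound 2 to compound 3 (0.12 log units; within the scatter).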

Compound 3, inhibition constant: 0.6 nM
Beside the measured number, compound 3's estimate is 1.3-fold (0.12 log units) above it; low and high end bracket the measured number.
By their numbers in this assay, from the lowest: compounds 1, 2 and 3 (each within the scatter of the next).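

In this assay the exchange of phenyl for trifluoromethyl on a saturated ring carbon, three ring bonds from the ring nitrogen, gives no change at the digits printed from compound 2 to compound 3 (within the scatter) and so shows that an aromatic ring of carbon at this position is not required to hold the read-out. The comparison of the whole amines gives no change at the digits printed from compound 1 to compound 3 (within the scatter) and extends the earlier result to a third amine, one whose substituent has no ring. Nothing at hand bears on why this position accepts both groups.

Still open, going by these compounds, is whether a carboxylic acid or a primary amine on this same ring carbon would keep the read-out in this range. Also open, on these data alone, is whether morpholin-4-yl in place of the whole amine would do the same.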